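Removing the bromoacetyl group from compound 1

The source may hold more compounds than are shown below. What is called first, only, known or untested is meant among the compounds shown, and "the series" means these compounds.

Compound 1 `O=C(CBr)Nc1ccc(C(=O)/C=C/c2cn(Cc3ccc(Br)cc3)nn2)cc1` was tested in a functional assay on MCF7 cells (Homo sapiens) for inhibition, read by MTT assay (a higher number here means a weaker inhibitor, a lower number a stronger inhibitor), where compound 1 gives 10100 nM. Within the data shown here, its companion compound 2 `CCCCCCCCCCn1cc(/C=C/C(=O)c2ccc(NC(=O)CBr)cc2)nn1` is the only other measured compound, and in this assay compound 2 gives 9760 nM. Among the measured compounds shown here, the one measured step, a 1.0-fold lower number from compound 1 to compound 2 (0.01 log units; within the scatter), replaces the nonyl chain with the 4-bromophenyl group and leaves the number essentially unchanged, so compound 1 and compound 2 sit together within the scatter, and neither can be called the stronger inhibitor.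

The unmeasured compound 3 `Nc1ccc(C(=O)/C=C/c2cn(Cc3ccc(Br)cc3)nn2)cc1` differs from compound 1 at the other end of the shared core: hydrogen in place of (bromomethyl)carbonyl on a nitrogen on an aromatic ring. For the measured compounds named here, no measured step touches this nitrogen, since the one step known involves a different part of the molecule, so nothing measured bears directly on this change. With no guidance from the data, the expected step from compound 1 to compound 3 in this assay is estimated as a modest rise, a 2.0-fold higher number from compound 1 to compound 3 (0.30 log units; within the scatter), with wide uncertainty. Compound 3 is therefore expected to give about 20000 nM in this assay, within a range from 5000 nM to 80000 nM.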

Compound 3, half-maximal inhibitory concentration: 25300 nM
Compound 3: the middle estimate sits 1.3-fold (0.10 log units) below what was measured; low and high end bracket the measured number.
By their numbers in this assay, from the lowest: compounds 2 and 1 (each within the scatter of the next); then compound 3.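

Among these compounds, removing the (bromomethyl)carbonyl group from the nitrogen on the aromatic ring, so that ((bromomethyl)carbonyl)amino becomes amino, gives a 2.5-fold higher number from compound 1 to compound 3 (0.40 log units; beyond the scatter) in this assay and is the first change here to lie beyond the scatter, whereas the exchange of 4-bromophenyl for nonyl gave a 1.0-fold lower number from compound 1 to compound 2 (0.01 log units; within the scatter) and left the number in place. The step is modest, so this position does respond to the change, yet compound 3 still gives a measured number of 25300 nM without the (bromomethyl)carbonyl group, which shows that inhibition in this assay does not depend entirely on that group. Nothing at hand explains why the number rises with this change.

Going by these compounds, whether the step follows the bromine or the carbonyl stays open, and an acetyl or chloroacetyl group on this same nitrogen would separate the two. Also open, on these data alone, is whether removing the group has a step of similar size when the nonyl chain of compound 2 stands in place of 4-bromophenyl, since the step is known only on the core of compound 1.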